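Aryl swap on the vinyl sulfide series: compound 3

The compounds below may be only part of what the source reports. "The series", "measured", "known", "first", "only" and "open" are said of these compounds alone.

Measured so far:
compound 1 `Cc1ccc(S/C(=C/c2sccc2C)C(=O)c2ccc(Br)cc2)cc1`: 50000 nM
compound 2 `Cc1ccc(S/C(=C/c2c(O)cc(O)cc2O)C(=O)c2ccc(Br)cc2)cc1`: > 100000 nM

Both were run in a functional assay on DU-145 cells (Homo sapiens) for inhibition, read by trypan blue exclusion, with a stated time of 96 h; on this read-out lower numbers stand for stronger inhibition of growth and higher numbers for weaker inhibition of growth. From the compounds shown here alone, for compound 2 the result is a limit only, > 100000 nM, so its exact position on the numbers is unknown. Compound 1 gives 50000 nM, a number rather than a limit. Among the measured compounds shown here, the one measured step is an at least 2.0-fold higher number from compound 1 to compound 2 (0.30 log units; that floor lies within the scatter); as a step it rests on (the limit of > 100000 nM in this assay, at which 1 of the 2 values shown sits), and its floor falls inside the usual scatter, so the true size of the change is not settled. For the measured compounds named here, what is clear is only that compound 2 sits at or beyond the limit, while compound 1 sits inside the measurable range.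

Compound 3 `Cc1ccc(S/C(=C/c2ccc(F)cc2F)C(=O)c2ccc(Br)cc2)cc1` differs from compound 2 as follows: 2,4-difluorophenyl in place of 2,4,6-trihydroxyphenyl on a double-bonded chain carbon bound to a double-bonded chain carbon. The aryl that enters, like the group in compound 1, carries no hydrogen-bond donors or acceptors, whereas the group that leaves carried three of each. Going by the values given here, the single measured step bears only loosely on this change, since it runs in the opposite direction and has no fixed size.

Compound 3 is therefore expected to return into the measurable range, with an estimated step of an at least 2.5-fold lower number from compound 2 to compound 3 (0.39 log units; beyond the scatter). The estimate for compound 3 is 40000 nM, with a range from 15000 nM to 100000 nM.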

Compound 3, concentration for 50% growth inhibition: > 100000 nM
Compound 3 was reported as a limit; the forecaster's own chance of this, stated with the estimate: 25%; middle value at least 2.5-fold (0.39 log units) from the limit.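

Working notes on this place in the series: a group with no hydrogen-bond donors or acceptors, 2,4-difluorophenyl, gives a result that stays at the assay limit in this assay, as 2,4,6-trihydroxyphenyl does, so a count of zero donors and acceptors alone does not bring a compound into the measurable range. Against the one number in the set, the change reads as an at least 2.0-fold higher number from compound 1 to compound 3 (0.30 log units; that floor lies within the scatter), which leaves 3-methylthiophen-2-yl as the only group shown that gives a value inside the range, though the floor of that step does not establish a real difference. The step between the two limit compounds, compound 2 and compound 3, cannot be read, and both results are limits and not numbers: the limit of > 100000 nM in this assay, at which 2 of the 3 values shown sit.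

Still open, from the compounds shown here alone, is how far beyond the limit compound 2 and compound 3 lie, and so whether these two groups differ at all at this place. Also open, going by these compounds, is whether the measurable value of compound 1 depends on the methyl group of 3-methylthiophen-2-yl, which an unsubstituted thiophen-2-yl or a 4-methylphenyl on the same carbon would help to separate.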